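Five-membered heteroaryl variation at the imidazoline ether core

This account rests on a few compounds, and the source may have more. Where it says the series, first, only, none or still open, it means among the compounds named here.

Measured compounds:
compound 1 `c1cnc(-c2ccccc2OCC2=NCCN2)nc1`: < 100000 nM
compound 2 `c1c[nH]c(-c2ccccc2OCC2=NCCN2)c1`: 6.31 nM
compound 3 `c1ccc(-c2cc[nH]n2)c(OCC2=NCCN2)c1`: < 100000 nM

In a functional assay for activation of Alpha-1D adrenergic receptor (Homo sapiens), read by calcium flux (a lower number here means that less compound is needed, a higher number that more compound is needed for the effect), compound 2 gives 6.31 nM. For compound 1 the value of < 100000 nM is a limit of the assay, not a number. For compound 3 the value of < 100000 nM is likewise a limit of the assay. Compound 3 therefore stands at the limit and nowhere on a readable scale; the same holds for the companion value, as the limit of < 100000 nM in this assay, at which 2 of the 3 values shown sit, records. The steps a step that the limit leaves unreadable from compound 1 to compound 2, a step that the two limits leave unreadable from compound 1 to compound 3 and a step that the limit leaves unreadable from compound 2 to compound 3 are all unreadable in size for this reason.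

Compound 4 `Cc1ccc(-c2ccccc2OCC2=NCCN2)s1` is the next point. The change from compound 3 is 5-methylthiophen-2-yl in place of 1H-pyrazol-3-yl on an aromatic carbon. Among the measured compounds shown here, no measured step bears on this change with a readable size: every step that starts or ends at a limit is silent, and compound 2 alone provides a number. The expectation for compound 4 in this assay is therefore broad. Compound 4 is estimated at 150 nM, with a range from 5 nM to 5000 nM. The step that the limit leaves unreadable from compound 3 to compound 4 is the expected move from compound 3, which cannot be compared with any measured step.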

Compound 4, half-maximal effective concentration: < 100000 nM
Compound 4: a limit, no number (the forecaster's own chance of this, stated with the estimate: 25%); the middle value does not contradict the limit.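

In this assay compound 4 gives < 100000 nM, which is a limit of the assay and not a number, so no step linking compound 4 with compound 1, compound 2 or compound 3 can be read: the limit of < 100000 nM in this assay, at which 3 of the 4 values shown sit.

The compounds shown leave open whether any group other than 1H-pyrrol-2-yl on the shared core gives a readable value in this assay.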